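From 4-chlorophenyl to 4-fluorophenyl at the assay limit

A few compounds are considered here, and "the series" means these few. Any claim that something is new, unique, unknown or untested is made for them only; others in the source may bear on it.

Compound 1 `COc1ccc(Nc2nc(N)c(C(=O)c3ccccc3)s2)cc1`: 850 nM
Compound 2 `COc1ccc(C(=O)c2sc(Nc3ccc(Cl)cc3)nc2N)cc1`: > 10000 nM
Compound 3 `Nc1nc(Nc2ccc(Cl)cc2)sc1C(=O)c1ccccc1`: > 10000 nM

These compounds were tested in a functional assay on L1210 cells (Mus musculus) for antiproliferative activity, read by cell counting, with a stated time of 2 days; a lower number here means a stronger inhibitor, a higher number a weaker inhibitor. Compound 1 gives a real number, 850 nM. Compound 2 gives > 10000 nM, which is a limit of the assay. Compound 3 gives > 10000 nM, which is also a limit and not a number. Compound 3 therefore stands at the limit of > 10000 nM in this assay, at which 2 of the 3 values shown sit.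

The next compound, compound 4 `Nc1nc(Nc2ccc(F)cc2)sc1C(=O)c1ccccc1`, differs from compound 3 by one change: fluoro in place of chloro on an aromatic carbon. The most relevant measured step is an at least 11-fold higher number from compound 1 to compound 3 (1.07 log units; beyond the scatter), with chloro in place of methoxy on an aromatic carbon. It shows that a change at this group can matter. The other step, a step that the two limits leave unreadable from compound 2 to compound 3, has hydrogen in place of methoxy on an aromatic carbon and gives no usable size. Among the measured compounds shown here, no measured step swaps chloro for fluoro, so only a modest move toward a lower number is expected in this assay, with compound 4 remaining weak. The expected step is an at least 1.6-fold lower number from compound 3 to compound 4 (0.22 log units; that floor lies within the scatter). Compound 4 is estimated at 6000 nM, with an expected range from 1200 nM to 10000 nM.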

Compound 4, half-maximal inhibitory concentration: > 10000 nM
Compound 4: only a limit was reported; the forecaster's own chance of this, stated with the estimate: 50%; middle value at least 1.6-fold (0.22 log units) away from the limit.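

In this assay, fluoro in place of methoxy at this position gives an at least 11-fold higher number from compound 1 to compound 4 (1.07 log units; beyond the scatter). The result for compound 4 is a limit of the assay and not a number, and the step from chloro to fluoro between compound 3 and compound 4 cannot be read, so these two groups cannot be ranked. What is new is that the large step is no longer tied to chloro alone, and at this position only the methoxy of compound 1 gives a real number: the limit of > 10000 nM in this assay, at which 3 of the 4 values shown sit.

From the compounds shown here alone, it remains open whether an ethoxy group, a hydroxyl group or an amine at this position would also give a real number, or whether methoxy is special. Going by these compounds, how weak compound 3 and compound 4 truly are also remains unknown.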